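One ring swapped on the amide nitrogen

The compounds below may be only part of what the source reports. "The series", "measured", "known", "first", "only" and "open" are said of these compounds alone.

Among the compounds with values here, in a physicochemical assay for lipophilicity (a lower number here means a more polar compound, a higher number a more lipophilic compound), compound 1 (`Cc1cnc(NC(=O)[C@H](COC(C)C)Oc2ncnc3c2cnn3-c2ccccc2Cl)cn1`) gives 2.1 as the lower of the two numbers so far, and compound 2 (`CC(C)OC[C@H](Oc1ncnc2c1cnn2-c1ncccc1Cl)C(=O)Nc1ccc(F)cn1`) stands higher at 2.7 by a gap beyond the usual scatter. Compound 3 (`CC(C)OC[C@H](Oc1ncnc2c1cnn2-c1ccccc1Cl)C(=O)Nc1ccccn1`) is still unmeasured and carries pyridin-2-yl in place of 5-methylpyrazin-2-yl on an amide-type nitrogen. Within the data shown here, no measured pair shows this swap alone, so the expectation is only a rough one. A moderate rise in this assay is expected, with an estimated size (a number 0.50 log units higher from compound 1 to compound 3 (beyond the scatter)) beyond the scatter. The estimated value for compound 3 is 2.6 (range 2.2 to 3).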

Compound 3, distribution coefficient: 3.5
For compound 3 the middle estimate is 0.90 log units below the measured one; the measured number lies above the stated range.
By their numbers in this assay, from the lowest: compound 1; then compound 2; then compound 3.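

Swapping 5-methylpyrazin-2-yl for pyridin-2-yl on the amide-type nitrogen gives the first direct reading of this position: in this assay the result is a number 1.40 log units higher from compound 1 to compound 3 (beyond the scatter) for this single change. The step is large, so this position is clearly not silent in this read-out. No measurement shown here explains its size.

The swap removes a methyl group and a ring nitrogen together, and the compounds shown leave open which of the two matters more. A 5-methylpyridin-2-yl group on the same nitrogen would separate them.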